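The compounds below may be only part of what the source reports. "The series", "measured", "known", "first", "only" and "open" are said of these compounds alone.

Measured so far:
- compound 1, `O=S(=O)(c1cc(Cl)cc(Cl)c1)c1cnc2c(F)cccc2c1-c1cccc(Cl)c1`, which in an ADME assay on microsomes from liver (Homo sapiens) for metabolic stability, tested at 2.5 uM (a lower number here means slower removal, a higher number faster removal of the compound), gives 1.2 mL/min
- compound 2, `O=S(=O)(c1cc(Cl)cc(Cl)c1)c1cnc2c(F)cccc2c1-c1ccc(F)cc1`, which in this assay gives 1.01 mL/min

Of these two numbers, compound 1 has the higher one, but the gap to compound 2 is a 1.2-fold lower number from compound 1 to compound 2 (0.07 log units; within the scatter), so the two compounds cannot be told apart by this measurement. Among the compounds with values here, the unmeasured compound 3, `N#Cc1cccc(S(=O)(=O)c2cnc3c(F)cccc3c2-c2cccc(Cl)c2)c1`, is built from compound 1 by a change at a different place from the one that separates compound 1 from compound 2: 3-cyanophenyl in place of 3,5-dichlorophenyl on a sulfonyl sulfur. Within the data shown here, the only step measured so far, a 1.2-fold lower number from compound 1 to compound 2 (0.07 log units; within the scatter), concerns the group on the aromatic carbon of the shared core rather than the group on the sulfonyl sulfur, so it bears on compound 3 only indirectly; what it does show is that one exchange of an aryl group on this core left the number essentially where it was. Nothing measured here speaks to an exchange on the sulfonyl sulfur itself. The expectation for compound 3 is therefore a step of a 1.3-fold lower number from compound 1 to compound 3 (0.10 log units; within the scatter), that is, no movement beyond the scatter. Compound 3 is estimated at 0.95 mL/min, with a range from 0.45 mL/min to 2 mL/min.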

Compound 3, intrinsic clearance in a liver preparation (reported as CLH), per the amount of preparation that the assay uses: 1.11 mL/min
Compound 3: middle estimate off by 1.2-fold (0.07 log units), on the low side; measured number inside the range.
By their numbers in this assay, from the lowest: compounds 2, 3 and 1 (each within the scatter of the next).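

In this assay, within the data shown here, the first measured exchange on the sulfonyl sulfur, 3-cyanophenyl in place of 3,5-dichlorophenyl, gives a 1.1-fold lower number from compound 1 to compound 3 (0.03 log units; within the scatter), so compound 1 and compound 3 cannot be told apart by this measurement. The group that enters has a nitrile and one hydrogen-bond acceptor, and the group that leaves has two chlorine atoms and no acceptor, yet this difference produces no step beyond the scatter. Alongside a 1.2-fold lower number from compound 1 to compound 2 (0.07 log units; within the scatter), this means that an aryl exchange at either of these two places has so far left the read-out within the scatter, and none of the three compounds goes against that; no measurement here offers an explanation for it.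

From the compounds shown here alone, both groups seen on the sulfonyl sulfur are phenyl rings with a substituent, so it remains open whether a piperidine, a short alkyl chain or a phenyl ring carrying an amine or a carboxylic acid would give a step beyond the scatter. Going by these compounds, it is also open what 3-cyanophenyl on the sulfonyl sulfur and 4-fluorophenyl on the aromatic carbon would give together in one molecule.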